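The compounds below may be only part of what the source reports. "The series", "measured", "known", "first", "only" and "open" are said of these compounds alone.

In a functional assay on HCT-116 cells (Homo sapiens) for antiproliferative activity, with a stated time of 48 h (on this read-out higher numbers stand for weaker inhibition and lower numbers for stronger inhibition), compound 1 `CCN(CC)c1ccc(-c2ccc(C(C)=O)cc2)nn1` gives 6000 nM. Compound 2 `CCN(CC)c1ccc(-c2ccc(C(=O)O)cc2)nn1` gives > 25000 nM, which is a limit of the assay and not a number. The place of compound 2 on the scale is therefore known only from the limit of > 25000 nM in this assay, at which 1 of the 2 values shown sits. Compound 3 `CCOC(=O)c1ccc(-c2ccc(N(CC)CC)nn2)cc1` has not yet been measured. It differs from compound 2 by ethyl in place of hydrogen on an oxygen next to a carbonyl group. This is ethyl in place of hydrogen on an oxygen next to a carbonyl group, so carboxy becomes ethoxycarbonyl. For the measured compounds named here, one measured step bears on this change: an at least 4.1-fold higher number from compound 1 to compound 2 (0.61 log units; beyond the scatter), with hydroxy in place of methyl on a carbonyl carbon. That step lies beyond the scatter and gave compound 2 its hydroxy, which the new change replaces with ethoxy. A move back toward a lower number, meaning stronger inhibition, is therefore expected in this assay, although a single step fixes its size only loosely. The estimate implies an at least 3.1-fold lower number from compound 2 to compound 3 (0.49 log units; beyond the scatter) as the expected step. For compound 3 the estimated value is 8000 nM, with an expected range from 3000 nM to 25000 nM.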

Compound 3, half-maximal inhibitory concentration: 500 nM
Compound 3: middle estimate off by 16-fold (1.20 log units), on the high side, outside the stated range (below it).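

In this assay putting ethyl in place of hydrogen on an oxygen next to a carbonyl group gives an at least 50-fold lower number from compound 2 to compound 3 (1.69 log units; beyond the scatter) and so more than undoes the loss seen with carboxy. For the compounds shown here, the earlier pair showed only that a change on this carbonyl carbon could weaken inhibition, whereas replacing methyl with ethoxy gives a 12-fold lower number from compound 1 to compound 3 (1.08 log units; beyond the scatter) and shows that a change here can also strengthen it. The first of these steps has no fixed size, as compound 2 stands at a limit of the assay and not at a number: the limit of > 25000 nM in this assay, at which 1 of the 3 values shown sits.

On these data alone, only methyl, hydroxy and ethoxy are compared on this carbonyl carbon, so it remains open whether the gain depends on the ethyl chain, on the oxygen that carries it, or on both together. As far as these compounds go, a methoxy group, a longer chain such as butoxy, or an amine forming an amide in the same place could help separate these possibilities, and how far the trend extends beyond these three compounds remains unknown.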